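From Cyclopropyl to Propyl in Compound 4

The source may report more compounds than this note shows. Statements on the series, on what has been measured and on what is new or still open speak of the compounds shown alone.

Measured in an ADME assay on Vero cells (Chlorocebus sabaeus) for cytotoxicity, read by MTT assay, with a stated time of 72 h; a higher number here means that more compound is tolerated, a lower number that less compound is tolerated:
Compound 1 `CCCNc1nc(NCCCCOc2nc(NCCC)nc(Nc3ccccc3)n2)nc(Nc2ccccc2)n1` gives 216000 nM
Compound 2 `c1ccc(Nc2nc(NCCCCOc3nc(Nc4ccccc4)nc(NC4CC4)n3)nc(NC3CC3)n2)cc1` gives "not determined" (no result reported)
Compound 3 `CCCNc1nc(Nc2ccccc2)nc(OCCCCNc2nc(Nc3ccccc3)nc(NC3CC3)n2)n1` gives > 400000 nM (a limit, not a number)

Compound 2 has no number to start from, and its entry in this assay reads "not determined" (no result reported). The only other reference points are the number for compound 1 and (the limit of > 400000 nM in this assay, at which 1 of the 3 values shown sits), which belongs to compound 3.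

Compound 4 `CCCNc1nc(NCCCCOc2nc(Nc3ccccc3)nc(NC3CC3)n2)nc(Nc2ccccc2)n1` is made from compound 2 by one swap, propyl in place of cyclopropyl on a nitrogen on an aromatic ring. Going by the values given here, one measured step bears on this, as it is the same kind of swap run in the opposite direction, and it gave an at least 1.8-fold higher number from compound 1 to compound 3 (0.26 log units; that floor lies within the scatter). Read backwards, that step points towards a lower number for compound 4 than for compound 2. However, no step beyond the scatter is expected, and without a number for compound 2 the step has no base to act on.

The expectation therefore rests on compound 1, at 216000 nM. Compound 3 stands at > 400000 nM, which is a limit. Compound 4 could also return only a limit. For compound 4 the expected value is 280000 nM, with an estimated range from 140000 nM to 400000 nM.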

Compound 4, half-maximal cytotoxic concentration: 18200 nM
Compound 4: middle estimate off by 15-fold (1.19 log units), on the high side, outside the stated range (below it).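

In this assay, putting cyclopropyl in place of propyl on a nitrogen on an aromatic ring gave a 12-fold lower number from compound 1 to compound 4 (1.07 log units; beyond the scatter), so this small change, which leaves the count of heavy atoms untouched and only closes a ring, can make the cells tolerate far less compound. The earlier step of the same kind gave an at least 1.8-fold higher number from compound 1 to compound 3 (0.26 log units; that floor lies within the scatter), and since compound 1 carries two propyl groups, compound 3 and compound 4 show that it matters which of the two is replaced: the name of the swap alone does not predict the outcome. Nothing among the results shown explains why the two places behave so differently.

Going by these compounds, the step between compound 2 and compound 4 cannot be read, as compound 2 has no number, so how cyclopropyl at both places compares with cyclopropyl at this one place stays open. Also open, on these data alone, is whether a larger ring such as cyclobutyl, or a longer chain such as butyl, on this nitrogen would follow cyclopropyl or propyl in this assay.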